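Methyl for fluoro on the aryl group of compound 2

The source may hold more compounds than are shown below. What is called first, only, known or untested is meant among the compounds shown, and "the series" means these compounds.

The shared core appears in compound 1 `COc1ccc(C2=C(c3ccc(SC)cc3)CC3CCCN3C2=O)cc1C` and compound 2 `CSc1ccc(C2=C(c3ccc(F)c(F)c3)C(=O)N3CCCC3C2)cc1` and also in the unmeasured compound 3 `CSc1ccc(C2=C(c3ccc(F)c(C)c3)C(=O)N3CCCC3C2)cc1` of this series. In a functional assay on DU-145 cells (Homo sapiens) for cytotoxicity (on this read-out higher numbers stand for weaker inhibition of growth and lower numbers for stronger inhibition of growth), compound 1 gives 900 nM and compound 2 gives 500 nM and these two numbers lie within the scatter of each other, so compound 2 stands level with compound 1.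

The change to compound 3 is methyl in place of fluoro on an aromatic carbon and turns 3,4-difluorophenyl into 4-fluoro-3-methylphenyl, with methyl in place of fluoro on an aromatic carbon. Within the data shown here, one measured step bears on it: the step of a 1.8-fold lower number from compound 1 to compound 2 (0.26 log units; within the scatter) came with 3,4-difluorophenyl in place of 4-methoxy-3-methylphenyl and stayed within the scatter. On that single step, the expected change is a 1.2-fold higher number from compound 2 to compound 3 (0.08 log units; within the scatter) and no shift beyond the scatter is expected in this assay for this exchange. Compound 3 is estimated at 600 nM with an expected range from 250 nM to 1400 nM as the likely span.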

Compound 3, concentration for 50% growth inhibition: 500 nM
For compound 3 the middle estimate is 1.2-fold (0.08 log units) above the measured one, and the stated range covers the measured number.
By their numbers in this assay, from the lowest: compounds 2, 3 and 1 (each within the scatter of the next).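

In this assay the aromatic carbon ortho to a fluoro group accepts methyl in place of fluoro, and no change at the digits printed from compound 2 to compound 3 (within the scatter) leaves the read-out within the scatter, so 4-fluoro-3-methylphenyl and 3,4-difluorophenyl cannot be told apart here. The earlier step changed two places on the aryl group at once, whereas a 1.8-fold lower number from compound 1 to compound 3 (0.26 log units; within the scatter) keeps the methyl and exchanges only methoxy for fluoro, and this single exchange also stays within the scatter. No measurement on hand gives a reason for either result.

Fluoro and methyl are both single heavy atoms, so the compounds shown leave open how this position responds to larger groups or groups of another kind, such as an ethyl group, an amine or a carboxylic acid. From the compounds shown here alone, whether any exchange on this aryl group moves the read-out beyond the scatter also remains open.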